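Working notes: compounds 1 to 4, chloro to methyl

The source may report more compounds than this note shows. Statements on the series, on what has been measured and on what is new or still open speak of the compounds shown alone.

Measured so far:
compound 1 `Cc1ccc(-c2cc3ccccc3[nH]2)cc1` — 9.33%
compound 2 `N#Cc1ccc2[nH]c(-c3ccccc3)cc2c1` — 82.3%
compound 3 `Clc1ccccc1-c1cc2ccccc2[nH]1` — 21.5%

In an assay on isolated protein for inhibition of Aromatase (Homo sapiens), read by fluorescence, using NADPH, with a stated time of 30 min, tested at 50 uM (on this read-out lower numbers stand for less inhibition and higher numbers for more inhibition at the one concentration tested (going by the name of the read-out)), compound 2 gives 82.3%, compound 3 gives 21.5% and compound 1 gives 9.33%. Compound 3 thus stands second highest of the three numbers: its nearest neighbour is compound 1, lower by a margin beyond the scatter, while compound 2 lies far higher, also beyond the scatter. For the measured compounds named here, no two measured compounds differ in a single place, so no step between them can be read off.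

Compound 4 `Cc1ccccc1-c1cc2ccccc2[nH]1` has not yet been measured in this assay. It differs from compound 3 by methyl in place of chloro on an aromatic carbon. Both groups count one heavy atom, bring no ring, no hydrogen-bond donors or acceptors and no charge, so what is counted changes little. Going by the values given here, the other methyl in the set, on compound 1, gives the lowest number, but no single-place step links compound 1 to compound 3. The step in this assay is expected to be small, within the scatter, and more likely downward than upward: a number 7.5 percentage points lower from compound 3 to compound 4 (within the scatter). The expected value for compound 4 is 14%, with a range from 3% to 28%.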

Compound 4, a percentage reported as inhibition, at one concentration (the size of the read-out at that concentration, not a potency): 27.1%
Compound 4: the middle estimate sits 13.1 percentage points below what was measured, within the range that was stated.
By their numbers in this assay, from the lowest: compound 1; then compounds 3 and 4 (each within the scatter of the next); then compound 2.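

In this assay, for the compounds shown here, methyl in place of chloro on an aromatic carbon, ortho to a group of 9 heavy atoms, gives a number 5.6 percentage points higher from compound 3 to compound 4 (within the scatter), the first single-place step. At this position, therefore, the exchange of these two groups, each of one heavy atom and neither bringing hydrogen-bond donors, acceptors or charge, does not separate the two compounds on this read-out. No measurement at hand speaks to the reason for this result.

As far as these compounds go, whether an amine, a carboxylic acid or a longer chain at this position would read apart from chloro and methyl remains open. Going by these compounds alone, compound 1 and compound 2 are joined to this pair by no single-place step, so steps to them cannot be read.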